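The source may report more compounds than this note shows. Statements on the series, on what has been measured and on what is new or still open speak of the compounds shown alone.

Measured compounds:
compound 1, `Cc1c(COCCCCOCC2(C)COC2)[nH]c2ccccc2c1=O`, 1200 nM
compound 2, `O=c1c(Cl)c(COc2cccc(OCC3CCOCC3)c2)[nH]c2ccccc12`, 12 nM
compound 3, `O=c1cc(COc2cccc(OCC3CCOCC3)c2)[nH]c2ccccc12`, 590 nM

All three were tested in a functional assay on HUVEC cells (Homo sapiens) for inhibition, using NADPH, with a stated time of 2 h; a higher number here means a weaker inhibitor, a lower number a stronger inhibitor. Compound 3 sits in the middle of the measured numbers: compound 2 gives 12 nM, compound 1 gives 1200 nM, and compound 3 with 590 nM lies between them, nearer to compound 1.

The next compound, compound 4, `CC(C)c1c(COc2cccc(OCC3CCOCC3)c2)[nH]c2ccccc2c1=O`, differs from compound 3 in one place: isopropyl in place of hydrogen on an aromatic carbon. Going by the values given here, only one measured step bears on this change, and it concerns the same kind of place, a substituent on an aromatic carbon of the shared core. That step, a 49-fold higher number from compound 2 to compound 3 (1.69 log units; beyond the scatter), shows that removing chloro from that carbon weakens inhibition markedly. Putting isopropyl onto the carbon in compound 4 goes in the opposite direction, so the number is expected to fall in this assay, though isopropyl is a different and larger group than chloro, and how far the loss is recovered cannot be read from a single step. A moderate to large drop is therefore expected, a 5.9-fold lower number from compound 3 to compound 4 (0.77 log units; beyond the scatter). Compound 4 is estimated at 100 nM, with a range from 20 nM to 600 nM.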

Compound 4, half-maximal inhibitory concentration: 54 nM
For compound 4 the middle estimate is 1.9-fold (0.27 log units) above the measured one; the range from low to high includes it.
By their numbers in this assay, from the lowest: compound 2; then compound 4; then compound 3; then compound 1.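

In this assay, placing isopropyl on this aromatic carbon instead of hydrogen gives an 11-fold lower number from compound 3 to compound 4 (1.04 log units; beyond the scatter), so the lower number at this position does not depend on chloro alone: two quite different groups, one a single atom and one with three carbons, both give a stronger inhibitor than hydrogen does. The two groups are not interchangeable, however, since replacing chloro with isopropyl gives a 4.5-fold higher number from compound 2 to compound 4 (0.65 log units; beyond the scatter), which means isopropyl recovers much of the ground lost on removing chloro but not all of it, and chloro keeps the lowest number among these closely matched compounds. Nothing measured here explains why either group lowers the number compared with hydrogen.

Going by these compounds, two groups on one carbon cannot show what the position prefers, so it remains open how bromo, a nitrile, cyclopropyl or an amine would fare there. Compound 1 differs from the others in more than one place, so it also leaves open whether a group on this carbon has the same effect when the side chain is different.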